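A few compounds are considered here, and "the series" means these few. Any claim that something is new, unique, unknown or untested is made for them only; others in the source may bear on it.

Compound 1, `CCS(=O)(=O)NC1CCCN(C(C)=O)C1COC1CCC(C(C)C)CC1` — in a functional assay on CHO-K1 cells for agonist activity at Orexin/Hypocretin receptor type 1 (Homo sapiens), read by FLIPR and calcium flux (on this read-out higher numbers stand for an effect only at larger amounts of compound and lower numbers for an effect already at smaller amounts), compound 1 gives > 100000 nM, which is a limit of the assay and not a number.
Compound 2, `CC(=O)N1CCC[C@H](NS(=O)(=O)C(C)C)[C@@H]1CO[C@H]1CC[C@@H](C(C)C)CC1` — compound 2 gives > 100000 nM, again a limit and not a number.
Compound 3, `CS(=O)(=O)N[C@H]1CCCN[C@H]1CO[C@H]1CC[C@@H](c2ccccc2)CC1` — compound 3 gives > 100000 nM, also a limit and not a number.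

Within the data shown here, all three values sit at the limit of > 100000 nM in this assay, at which 3 of the 3 values shown sit, so compound 3 has no number to be placed on, only this limit; no step between measured compounds can be read from these data. The change ethylcarbamoyl in place of hydrogen on an amine nitrogen in a ring gives compound 4, `CCNC(=O)N1CCC[C@H](NS(C)(=O)=O)[C@@H]1CO[C@H]1CC[C@@H](c2ccccc2)CC1`. With compound 1 and compound 2 also reaching only the limit, nothing here points to an effect appearing at smaller amounts. The step of a number no higher from compound 3 to compound 4 (the limit leaves the size open) is expected to be none beyond the scatter. Compound 4 is expected to give 100000 nM, with a range from 30000 nM to 300000 nM.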

Compound 4, half-maximal effective concentration: > 14000 nM
Compound 4: a limit, no number; the forecaster's own chance of this, stated with the estimate: 85%; the middle value does not contradict the limit.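

Among these compounds, compound 3 and compound 4 both give only limits of the assay and not numbers, so no step between them can be read. The compounds shown leave open at what amount, if any, each would act in this assay.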